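This account rests on a few compounds, and the source may have more. Where it says the series, first, only, none or still open, it means among the compounds named here.

Working notes on the series. Compound 1 `CCCCCNc1nc(Nc2ccc([N+](=O)[O-])cc2)nc(OCC(F)(F)F)n1` in an ADME assay on microsomes from liver (Rattus norvegicus) for metabolic stability, with a stated time of 10 min (on this read-out higher numbers stand for a more stable compound and lower numbers for a less stable compound), gives 35%. Compound 2 `O=C(NS(=O)(=O)CCNC(=O)C1CC1)c1ccc(Nc2nc(NC3(c4ccc(Cl)cc4)CC3)nc(OCC(F)(F)F)n2)cc1` in this assay gives "not active" (no number reported), so compound 2 stands without a number on this read-out and cannot be placed against compound 1. Compound 3 `CNC(=O)NCCS(=O)(=O)NC(=O)c1ccc(Nc2nc(NC3(c4ccc(Cl)cc4)CC3)nc(OCC(F)(F)F)n2)cc1` differs from compound 2 by methylamino in place of cyclopropyl on a carbonyl carbon. Among the measured compounds shown here, with no measured step between any two compounds, the size of the step from compound 2 to compound 3 in this assay is open; nothing beyond the scatter is assumed in either direction. Compound 3 is expected to give about 20%, within 3% to 55%.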

Compound 3, percent of the compound remaining: 100%
For compound 3 the middle estimate is 80 percentage points below the measured one; the whole stated range lies below it.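

No step can be read in this assay: compound 2 has no number there, so compound 3 cannot be set against it. From the compounds shown here alone, the size of the step from cyclopropyl to methylamino stays open, and no available evidence bears on the result.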